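This account rests on a few compounds, and the source may have more. Where it says the series, first, only, none or still open, it means among the compounds named here.

Three compounds share one core and differ only in the group on the aromatic ring attached to the sulfonamide nitrogen. Compound 1 `CCCCCc1ccc(NS(=O)(=O)c2ccc(N3CCNC3=O)cc2)cc1` carries a pentyl group; in a functional assay on MCF7 cells (Homo sapiens) for antiproliferative activity, read by sulforhodamine B assay, with a stated time of 48 h (on this read-out lower numbers stand for stronger inhibition and higher numbers for weaker inhibition), compound 1 gives > 1000 nM, which is a limit of the assay and not a number. Compound 2 `O=C1NCCN1c1ccc(S(=O)(=O)Nc2ccc(C3CCCCC3)cc2)cc1` carries a cyclohexyl group, and in this assay compound 2 gives > 1000 nM, again a limit rather than a number. Among the compounds with values here, compound 3 `O=C1NCCN1c1ccc(S(=O)(=O)Nc2ccc(Br)cc2)cc1` carries a bromo group, and in this assay compound 3 gives 240 nM, the only actual number among the three and so the point where the series stands. The step of an at least 4.1-fold lower number from compound 1 to compound 3 (0.61 log units; beyond the scatter) and the step of an at least 4.1-fold lower number from compound 2 to compound 3 (0.61 log units; beyond the scatter) both show that bromo in place of pentyl or cyclohexyl goes with a clearly lower number. Compound 4 `O=C1NCCN1c1ccc(S(=O)(=O)Nc2cccc(Cl)c2)cc1` is the next step: 3-chlorophenyl in place of 4-bromophenyl on a sulfonamide nitrogen. Within the data shown here, no measured step exchanges one halogen for another or moves a halogen on the ring; the two steps that exist only show that a halogen on this ring is compatible with the lowest number seen. The exchange is therefore expected to give a step of about a 1.7-fold higher number from compound 3 to compound 4 (0.22 log units; within the scatter), within the scatter. Compound 4 is estimated at 400 nM in this assay, with a range from 150 nM to 1500 nM.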

Compound 4, half-maximal inhibitory concentration: 79 nM
Compound 4: middle estimate off by 5.1-fold (0.70 log units), on the high side, outside the stated range (below it).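

In this assay, 3-chlorophenyl in place of 4-bromophenyl gives a 3.0-fold lower number from compound 3 to compound 4 (0.48 log units; beyond the scatter), so the choice of halogen-bearing ring on the sulfonamide nitrogen does more than merely allow a low number: it moves the number beyond the usual scatter. Within the data shown here, the earlier steps at this place all ran against a limit, and this is the first one whose size can be read from two actual numbers. The two groups have the same count of heavy atoms, and neither has any hydrogen-bond donors or acceptors, so the step appears with no difference in those counts.

The halogen and its place on the ring both change in this single step, and the compounds shown do not separate chloro in place of bromo from the move of the halogen. Also open is how a ring carrying an amine or a carboxylic acid would compare, and the pentyl and cyclohexyl compounds give no exact size to set beside these results: the limit of > 1000 nM in this assay, at which 2 of the 4 values shown sit.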